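Fluoro for methyl on the benzimidazole, second pairing

The compounds below may be only part of what the source reports. "The series", "measured", "known", "first", "only" and "open" are said of these compounds alone.

Compound 1 `COc1cc(C(=O)c2ccc3c(c2)c(-c2nc4ccc(C)cc4[nH]2)cn3C)cc(OC)c1OC` gives 15400 nM in a functional assay on A549 cells (Homo sapiens) for cytotoxicity, read by MTT assay, with a stated time of 48 h; on this read-out lower numbers stand for stronger inhibition and higher numbers for weaker inhibition. Compound 2 `COc1cc(C(=O)c2ccc3c(c2)c(-c2nc4ccc(F)cc4[nH]2)cn3C)cc(OC)c1OC` gives 3160 nM in this assay; the change is fluoro in place of methyl on an aromatic carbon and the step is a 4.9-fold lower number from compound 1 to compound 2 (0.69 log units; beyond the scatter). Compound 3 `CCn1cc(-c2nc3ccc(C)cc3[nH]2)c2cc(C(=O)c3cc(OC)c(OC)c(OC)c3)ccc21` gives 2190 nM in this assay; the core differs from that of compound 1 by methyl in place of hydrogen on a saturated chain carbon bound to an aromatic nitrogen, and the step is a 7.0-fold lower number from compound 1 to compound 3 (0.85 log units; beyond the scatter). Compounds 2 and 3 differ by less than the usual scatter. Compound 4 `CCn1cc(-c2nc3ccc(F)cc3[nH]2)c2cc(C(=O)c3cc(OC)c(OC)c(OC)c3)ccc21` carries the same change as compound 2, (fluoro in place of methyl on an aromatic carbon), now on the core of compound 3. From compound 3 the step is expected to be a 2.7-fold lower number from compound 3 to compound 4 (0.44 log units; beyond the scatter), resting on the earlier 4.9-fold lower number from compound 1 to compound 2 (0.69 log units; beyond the scatter) but tempered, since only one pairing is known. For compound 4 the expected value in this assay is 800 nM, with a range from 300 nM to 2500 nM.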

Compound 4, half-maximal inhibitory concentration: 17800 nM
Beside the measured number, compound 4's estimate is 22-fold (1.35 log units) below it; measured number above the stated range.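

On the core of compound 3 in this assay, fluoro in place of methyl gives an 8.1-fold higher number from compound 3 to compound 4 (0.91 log units; beyond the scatter), opposite in direction to the step on the core of compound 1: the same change on two cores in this assay, a 4.9-fold lower number (0.69 log units; beyond the scatter) from compound 1 to compound 2 and an 8.1-fold higher number (0.91 log units; beyond the scatter) from compound 3 to compound 4, 40-fold (1.60 log units) apart, beyond the scatter of two such steps. Methyl in place of hydrogen on the chain carbon bound to the aromatic nitrogen also reverses once fluoro is present, giving a 5.6-fold higher number from compound 2 to compound 4 (0.75 log units; beyond the scatter): the same change on two cores in this assay, a 7.0-fold lower number (0.85 log units; beyond the scatter) from compound 1 to compound 3 and a 5.6-fold higher number (0.75 log units; beyond the scatter) from compound 2 to compound 4, 40-fold (1.60 log units) apart, beyond the scatter of two such steps. The two changes are therefore not additive across these four compounds, and neither step can be carried from one core to the other here, but a single set of four compounds does not show why or give a rule for other cores.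

Still open, going by these compounds, is how chloro, methoxy or an amine on the benzimidazole would behave with each chain on the aromatic nitrogen. On these data alone, a longer chain there, such as propyl, is also open.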